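Swapping a Hydroxyphenyl for an Ethylphenyl on the Sulfonamide

The compounds below may be only part of what the source reports. "The series", "measured", "known", "first", "only" and "open" are said of these compounds alone.

Of the compounds shown here, three built around a shared core have been tested in an assay on isolated protein for inhibition of malate dehydrogenase, mitochondrial (Sus scrofa), with stated times of 45 min and 30 min; a lower number here means a stronger inhibitor, a higher number a weaker inhibitor. Compound 1 `O=S(=O)(Nc1ccc(-c2nc3ccccc3o2)cc1)c1cccc(O)c1` reaches only the limit of > 63000 nM in this assay, which is a bound of the measurement and not a number. Compound 2 `O=S(=O)(Nc1ccc2oc(-c3ccccc3)nc2c1)c1ccc(Cl)cc1` likewise stops at the limit of > 63000 nM in this assay. Compound 3 `COc1ccc(Cl)cc1S(=O)(=O)Nc1ccc2oc(-c3ccccc3)nc2c1` too gives just the limit of > 63000 nM in this assay. The only change measured between two of these compounds, a step that the two limits leave unreadable from compound 2 to compound 3, cannot be sized, as both of its ends rest on a limit. Going by the values given here, in short, every value so far sits at the same bound: the limit of > 63000 nM in this assay, at which 3 of the 3 values shown sit.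

Compound 4 `CCc1ccc(S(=O)(=O)Nc2ccc(-c3nc4ccccc4o3)cc2)cc1` has not yet been measured. It differs from compound 1 in one place: 4-ethylphenyl in place of 3-hydroxyphenyl on a sulfonyl sulfur. Among the compounds with values here, no measured step resembles this exchange, and the one step that is known was itself unreadable, so no direction can be drawn from it. Since compound 1 itself shows only the limit of > 63000 nM, compound 4 is expected to end up at that same limit as well. The expected step that the limit leaves unreadable from compound 1 to compound 4 is therefore none that the measurement could reveal. Compound 4 is estimated at 100000 nM, with a range from 30000 nM to 500000 nM, most likely reported only as a limit.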

Compound 4, half-maximal inhibitory concentration: > 63000 nM
Compound 4: a limit, no number; the forecaster's own chance of this, stated with the estimate: 85%; the middle value is on the limit's open side.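

Compound 1 and compound 4 both rest on a limit and not on a number, so the step between them cannot be read in this assay, and all values remain at one bound: the limit of > 63000 nM in this assay, at which 4 of the 4 values shown sit.

The compounds shown leave open which structure, if any, would give an actual number in this assay, and so how any of compound 1, compound 2, compound 3 and compound 4 rank against one another.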